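The source may report more compounds than this note shows. Statements on the series, on what has been measured and on what is new or still open speak of the compounds shown alone.

Of the compounds shown here, three sharing one core have been measured in an ADME assay on LLC-MK2 cells (Macaca mulatta) for cytotoxicity, read by spectrophotometry and crystal violet staining, with a stated time of 4 days; a lower number here means that less compound is tolerated, a higher number that more compound is tolerated. Compound 1 `CC(C)n1ncc2c(C(=O)Nc3ccc(F)c(S(N)(=O)=O)c3)cc(-c3cccs3)nc21` gives 50000 nM, compound 2 `CC(C)n1ncc2c(C(=O)Nc3cccc(F)c3F)cc(-c3cccs3)nc21` gives 75000 nM, and compound 3 `CC(C)n1ncc2c(C(=O)N3CCc4cccnc43)cc(-c3cccs3)nc21` gives 50000 nM. Compound 3 stands level with compound 1, the two together the lowest of the three numbers, and the step of a 1.5-fold lower number from compound 2 to compound 3 (0.18 log units; within the scatter) separates it from compound 2. Compound 4 `CC(C)n1ncc2c(C(=O)Nc3cncnc3)cc(-c3cccs3)nc21` differs from compound 3 by a group of 7 heavy atoms (4 carbon, 3 nitrogen; one six-membered aromatic ring with 2 hetero atoms) in place of a group of 9 heavy atoms (7 carbon, 2 nitrogen; one five-membered non-aromatic ring with 1 hetero atom, one six-membered aromatic ring with 1 hetero atom), on a carbonyl carbon. For the measured compounds named here, only one earlier step bears on this place, the exchange on the carbonyl carbon a 1.5-fold lower number from compound 2 to compound 3 (0.18 log units; within the scatter), and compound 1 also carries an aromatic amine there at the same number as compound 3. The change from compound 3 to compound 4 is therefore expected to be no change at the digits printed from compound 3 to compound 4 (within the scatter). Compound 4 is estimated at 50000 nM, between 25000 nM and 100000 nM.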

Compound 4, half-maximal cytotoxic concentration: 20000 nM
Beside the measured number, compound 4's estimate is 2.5-fold (0.40 log units) above it, and the stated range ends above it.
By their numbers in this assay, from the lowest: compound 4; then compounds 1, 3 and 2 (each within the scatter of the next).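

The carbonyl carbon is a place where the number can move beyond the scatter in this assay, which the earlier exchange there did not show. Bringing in (pyrimidin-5-yl)amino gives a 2.5-fold lower number from compound 3 to compound 4 (0.40 log units; beyond the scatter) and is a modest step, while pyrimidin-5-yl in place of 2,3-difluorophenyl on the amide-type nitrogen gives a 3.8-fold lower number from compound 2 to compound 4 (0.57 log units; beyond the scatter) and is also modest. No measured evidence here accounts for these steps. On these data alone, it remains open how a morpholine on this carbonyl carbon, or a pyridin-3-yl on the amide-type nitrogen, would read in this assay.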